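Hydroxy added to the methyl compound: working notes

This account rests on a few compounds, and the source may have more. Where it says the series, first, only, none or still open, it means among the compounds named here.

Measured in a functional assay on PC-3 cells (Homo sapiens) for inhibition, read by sulforhodamine B assay; a lower number here means a stronger inhibitor of growth, a higher number a weaker inhibitor of growth:
- compound 1 `c1ccc(-c2ccc(-c3ccc(-c4nc5ccccc5[nH]4)cc3)cc2)cc1`: 41200 nM
- compound 2 `Oc1ccc(-c2ccc(-c3ccc(-c4nc5ccccc5[nH]4)cc3)cc2)cc1`: 47000 nM
- compound 3 `Cc1ccc2[nH]c(-c3ccc(-c4ccc(-c5ccccc5)cc4)cc3)nc2c1`: 100000 nM

Compound 3 has the highest number of the three in this assay and lies beyond the scatter from both of the others. Methyl in place of hydrogen on an aromatic carbon gave a 2.4-fold higher number from compound 1 to compound 3 (0.39 log units; beyond the scatter).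

The next compound is compound 4 `Cc1ccc2[nH]c(-c3ccc(-c4ccc(-c5ccc(O)cc5)cc4)cc3)nc2c1`. It differs from compound 3 by hydroxy in place of hydrogen on an aromatic carbon. In words, this is hydroxy in place of hydrogen on an aromatic carbon, or phenyl to 4-hydroxyphenyl.

One measured step carries the same change: a 1.1-fold higher number from compound 1 to compound 2 (0.06 log units; within the scatter). It was measured without the methyl group and is a single example. The data do not show whether it holds in the presence of methyl. The methyl step gives the starting level for compound 3 but says nothing direct about hydroxy. On this evidence, no step beyond the scatter is expected in this assay, in either direction. The expected change is a 1.1-fold lower number from compound 3 to compound 4 (0.05 log units; within the scatter). The estimated value for compound 4 is 90000 nM, with an expected range from 45000 nM to 160000 nM.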

Compound 4, concentration for 50% growth inhibition: 30000 nM
The estimate for compound 4 lay 3.0-fold (0.48 log units) above the measured number; measured number below the stated range.
By their numbers in this assay, from the lowest: compounds 4, 1 and 2 (each within the scatter of the next); then compound 3.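

With methyl on the core, phenyl to 4-hydroxyphenyl gives a 3.3-fold lower number from compound 3 to compound 4 (0.52 log units; beyond the scatter) in this assay, so the effect of this change differs with the methyl group present and cannot be carried over from the core without it: the same change on two cores in this assay, a 1.1-fold higher number (0.06 log units; within the scatter) from compound 1 to compound 2 and a 3.3-fold lower number (0.52 log units; beyond the scatter) from compound 3 to compound 4, 3.8-fold (0.58 log units) apart, beyond the scatter of two such steps. The methyl change also reads differently once hydroxy is present, where it gives a 1.6-fold lower number from compound 2 to compound 4 (0.19 log units; within the scatter), and the higher number seen for methyl on the core without hydroxy does not recur: the same change on two cores in this assay, a 2.4-fold higher number (0.39 log units; beyond the scatter) from compound 1 to compound 3 and a 1.6-fold lower number (0.19 log units; within the scatter) from compound 2 to compound 4, 3.8-fold (0.58 log units) apart, beyond the scatter of two such steps. Within these four compounds, the hydroxy and methyl changes therefore do not act as independent, additive steps, although each comparison rests on a single pair.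

The compounds shown leave open whether this dependence is particular to hydroxy or would also appear with methoxy or an amine in the same place on the methyl core. They also leave open whether ethyl or chlorine in place of methyl would couple with hydroxy in the same way.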